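The source may report more compounds than this note shows. Statements on the series, on what has been measured and on what is new or still open speak of the compounds shown alone.

In a physicochemical assay for solubility, measured as kinetic solubility (on this read-out lower numbers stand for lower solubility and higher numbers for higher solubility), compound 1 `O=C(CCCN1CCCCCC1)Nc1cnc(-c2ccc(F)cc2F)s1` stands at > 97 ug/mL, which is a limit and not a number. Compound 2 `O=C(CCCN1CCCCC1)Nc1cnc(-c2ccc(F)cc2)s1`, which carries the 4-fluorophenyl, gives > 94 ug/mL, also a limit. For the measured compounds named here, no measured step is available in this small set, so the effect of the change has no direct precedent here. Compound 3 `O=C(CCCN1CCCCCC1)Nc1cnc(-c2ccc(F)cc2)s1` comes from compound 1 by the change from 2,4-difluorophenyl to 4-fluorophenyl, with hydrogen in place of fluoro on an aromatic carbon, ortho to a large group: hydrogen in place of fluoro on an aromatic carbon. In this assay, no step beyond the scatter is expected, in either direction. The expectation rests on compound 2 at > 94 ug/mL, again only a limit. The expected change is an at least 1.0-fold lower number from compound 1 to compound 3 (0.00 log units; that floor lies within the scatter), and compound 3 will probably also be reported as a limit. For compound 3 the estimate is 95 ug/mL, with an expected range of 60 ug/mL to 105 ug/mL.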

Compound 3, solubility: > 97 ug/mL
Compound 3: a limit, no number; the forecaster's own chance of this, stated with the estimate: 80%; middle value at least 1.0-fold (0.00 log units) away from the limit.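

In this assay compound 3 is reported as a limit, as are compound 1 and compound 2, so neither the step from compound 1 nor the step from compound 2 can be read. The compounds shown leave open whether hydrogen in place of fluoro, or azepan-1-yl in place of piperidin-1-yl, shifts this read-out at all.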